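Swapping ethynyl for fluoro on a thiourea-linked anilide

The compounds below may be only part of what the source reports. "The series", "measured", "known", "first", "only" and "open" are said of these compounds alone.

Within the data shown here, in a functional assay on NCI-H1975 cells (Homo sapiens) for antiproliferative activity, read by MTT assay, with a stated time of 72 h (on this read-out higher numbers stand for weaker inhibition and lower numbers for stronger inhibition), compound 2 `C#Cc1cccc(Nc2ncnc3ccc(NC(=S)Nc4ccc(S(N)(=O)=O)cc4)cc23)c1` gives 13400 nM, the only actual number among the compounds measured here. Compound 1 `COc1cc2ncnc(Nc3ccc(F)cc3)c2cc1OCCCCC(=O)Nc1ccc(S(N)(=O)=O)cc1` reaches only (the limit of > 40000 nM in this assay, at which 1 of the 2 values shown sits), so its entry > 40000 nM is a limit of the assay and not a number. Compound 3 `NS(=O)(=O)c1ccc(NC(=S)Nc2ccc3ncnc(Nc4cccc(F)c4)c3c2)cc1` differs from compound 2 by fluoro in place of ethynyl on an aromatic carbon. Among the measured compounds shown here, no measured step covers this change, so the expectation is a modest weakening, perhaps beyond the usual scatter, as a 1.9-fold higher number from compound 2 to compound 3 (0.27 log units; within the scatter). Compound 3 is therefore estimated at 25000 nM, within 8000 nM to 80000 nM.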

Compound 3, half-maximal inhibitory concentration: 9660 nM
For compound 3 the middle estimate is 2.6-fold (0.41 log units) above the measured one; measured number inside the range.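

Going from 3-ethynylphenyl to 3-fluorophenyl gives, in this assay, a 1.4-fold lower number from compound 2 to compound 3 (0.14 log units; within the scatter). At this place on the ring, then, fluoro stands in for ethynyl with no difference that can be told apart, so the triple bond is not needed to keep this level of activity in this pair. Nothing measured here accounts for this.

Going by these compounds, whether a methoxy, an amine or a carboxylic acid at the same place would shift the number beyond the scatter stays open. So does the effect of a urea in place of the thiourea link.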